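Notes on compound 3, an analogue of compound 1

A few compounds are considered here, and "the series" means these few. Any claim that something is new, unique, unknown or untested is made for them only; others in the source may bear on it.

Compound 1 `Cn1nccc1-c1ccccc1NCC1=NCCN1` is the reference point of this pair. In an in vitro functional assay on cells (Fibroblast) for agonist activity at Alpha-1A adrenergic receptor (Homo sapiens) (on this read-out lower numbers stand for an effect already at smaller amounts and higher numbers for an effect only at larger amounts of compound), compound 1 gives 10 nM, the lowest of the two numbers available. Within the data shown here, compound 2 `CCn1nccc1-c1ccccc1NCC1=NCCN1` is the only other measured member; in this assay compound 2 gives 63.1 nM. Among the measured compounds shown here, the single measured step is a 6.3-fold higher number from compound 1 to compound 2 (0.80 log units; beyond the scatter), methyl in place of hydrogen on a saturated chain carbon bound to an aromatic nitrogen.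

Compound 3 `Cc1n[nH]c(-c2ccccc2NCC2=NCCN2)n1` differs from compound 1 by 3-methyl-1H-1,2,4-triazol-5-yl in place of 1-methyl-1H-pyrazol-5-yl on an aromatic carbon. For the measured compounds named here, no measured step reproduces this change; the step from compound 1 to compound 2 alters the same part of the structure, but in another way, and shows only that a small change there shifted the number modestly. The expected step is therefore a 3.0-fold higher number from compound 1 to compound 3 (0.48 log units; beyond the scatter), with wide uncertainty in both directions. Compound 3 is estimated at 30 nM, within a range of 5 nM to 200 nM.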

Compound 3, half-maximal effective concentration: 794 nM
For compound 3 the middle estimate is 26-fold (1.42 log units) below the measured one; measured number above the stated range.
By their numbers in this assay, from the lowest: compound 1; then compound 2; then compound 3.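

In this assay, among these compounds, the exchange of 1-methyl-1H-pyrazol-5-yl for 3-methyl-1H-1,2,4-triazol-5-yl is a large step (a 79-fold higher number from compound 1 to compound 3 (1.90 log units; beyond the scatter)), whereas the only earlier step at this group was modest (a 6.3-fold higher number from compound 1 to compound 2 (0.80 log units; beyond the scatter)). This place on the six-membered aromatic ring therefore responds more strongly to this swap of one five-membered aromatic ring for another, with the same count of heavy atoms, than to the extra methyl of compound 2. The swap brings in one more ring nitrogen and a hydrogen-bond donor, and nothing available bears on which of these differences goes with the higher number.

The compounds shown do not separate the ring nitrogen from the donor hydrogen, which a methyl-substituted triazole without the ring hydrogen could address. Going by these compounds, how a pyridine ring or a primary amide would read at this place also remains open.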